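Working notes: amide substituent change from compound 3

This account rests on a few compounds, and the source may have more. Where it says the series, first, only, none or still open, it means among the compounds named here.

Measured in a functional assay on MDA-MB-435 cells (Homo sapiens) for cytotoxicity, read by MTT assay, with a stated time of 72 h; a higher number here means a weaker inhibitor, a lower number a stronger inhibitor:
- compound 1 `N[C@H]1CC[C@H](Nc2c(C(=O)NCc3ccc(Oc4ccccc4)cc3)nc(Br)c3cccnc23)CC1`: 4000 nM
- compound 2 `Nc1ccc(Nc2c(C(=O)NCc3ccc(F)cc3)nc(Br)c3cccnc23)cc1`: 7000 nM
- compound 3 `N[C@H]1CC[C@H](Nc2c(C(=O)NCc3ccc(Cl)cc3)nc(Br)c3cccnc23)CC1`: 1000 nM

Compound 3 has the lowest number of the three, and its gaps to compound 1 and compound 2 both lie beyond the scatter. Compound 4 `N[C@H]1CC[C@H](Nc2c(C(=O)Nc3ccccc3)nc(Br)c3cccnc23)CC1` is not yet measured. It departs from compound 3 by phenyl in place of 4-chlorobenzyl on an amide-type nitrogen.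

Going by the values given here, only one measured step bears on this change, and only loosely: a 4.0-fold lower number from compound 1 to compound 3 (0.60 log units; beyond the scatter), with chloro in place of phenoxy on an aromatic carbon. Among the compounds with values here, no measured compound carries phenyl on that nitrogen, so the evidence is thin. A modest step of similar size is expected, and an upward direction is expected with compound 3 at 1000 nM already lowest. The expected step is a 3.0-fold higher number from compound 3 to compound 4 (0.48 log units; beyond the scatter). For compound 4 the estimated value is 3000 nM, with an expected range of 1000 nM to 10000 nM.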

Compound 4, half-maximal inhibitory concentration: 1000 nM
Estimate against measurement, compound 4: 3.0-fold (0.48 log units) above; the measured number falls inside the stated range.
By their numbers in this assay, from the lowest: compounds 3 and 4 (each within the scatter of the next); then compounds 1 and 2 (each within the scatter of the next).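

In this assay, phenyl in place of 4-chlorobenzyl on the amide-type nitrogen gives no change at the digits printed from compound 3 to compound 4 (within the scatter), so at this position anilino and (4-chlorobenzyl)amino cannot be told apart. Going by these compounds alone, the earlier step, a 4.0-fold lower number from compound 1 to compound 3 (0.60 log units; beyond the scatter), showed only that the number responds to a change on the aromatic carbon of the benzyl group; the new step shows that a shorter substituent without the chlorine can match compound 3 in this cell assay. No measured evidence explains this equivalence.

From the compounds shown here alone, a plain benzyl on the same nitrogen would separate the contribution of the chlorine from that of the extra carbon, and this remains open. Also open, going by these compounds, is whether an amine or a carboxylic acid on the phenyl of compound 4 would shift the number.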